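The source may report more compounds than this note shows. Statements on the series, on what has been measured and on what is new or still open speak of the compounds shown alone.

Working notes on the series.

Compound 1 `CN(C)c1cc2[nH]c(C3CCCCC3)nc2cc1NC(=O)c1ccc(Br)cc1` is the point of departure. In an ADME assay on Vero cells (Chlorocebus sabaeus) for cytotoxicity, read by resazurin assay, with a stated time of 3 days (a lower number here means a stronger inhibitor, a higher number a weaker inhibitor), compound 1 gives > 100 ug/mL, which is a limit of the assay rather than a number. Compound 2 `O=C(Nc1cc2nc(C3CCCCC3)[nH]c2cc1N1CCCC1)c1ccc(Br)cc1` gives > 100 ug/mL in this assay, again a limit. Compound 3 `Cc1ccc(C(=O)Nc2cc3nc(C4CCCCC4)[nH]c3cc2N2CCCC2)cc1` gives > 100 ug/mL in this assay, also a limit. Accordingly the step that the two limits leave unreadable from compound 1 to compound 2 and the step that the two limits leave unreadable from compound 2 to compound 3 cannot be sized; what the three values show together is the limit of > 100 ug/mL in this assay, at which 3 of the 3 values shown sit.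

Compound 4 `CN(C)c1cc2[nH]c(C3CCCCC3)nc2cc1NC(=O)c1cccs1` has not yet been measured. It differs from compound 1 in one place: thiophen-2-yl in place of 4-bromophenyl on a carbonyl carbon. Among the measured compounds shown here, the step from compound 2 to compound 3 also touches the carbonyl-bound aryl group, but its size is not readable, so no measured step gives a usable size for the change from compound 1 to compound 4. Because (the limit of > 100 ug/mL in this assay, at which 3 of the 3 values shown sit), no step beyond the scatter is expected in this assay, and a further limit is the most likely outcome. Compound 4 is estimated at 100 ug/mL in this assay, with a range from 50 ug/mL to 200 ug/mL. The expected step is then a number no higher from compound 1 to compound 4 (the limit leaves the size open).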

Compound 4, half-maximal inhibitory concentration: > 100 ug/mL
Compound 4: only a limit was reported; the forecaster's own chance of this, stated with the estimate: 85%; the middle value lies on the limit itself.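

Compound 4 gives > 100 ug/mL in this assay, which is a limit. Among the compounds shown here, no step from compound 1 to compound 4 can be read, and the series stands at: the limit of > 100 ug/mL in this assay, at which 4 of the 4 values shown sit. The compounds shown leave open what actual number any of them would give in this assay, and so whether any of these changes has an effect there.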